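Furan-2-yl Amide on the Quinoline Core: Expected Antiproliferative Potency

The compounds below may be only part of what the source reports. "The series", "measured", "known", "first", "only" and "open" are said of these compounds alone.

Compound 1 `Cc1cc(NCCN(C)C)nc2ccc(NC(=O)c3ccc(Cl)c(Cl)c3)cc12`: 6670 nM
Compound 2 `CCc1ccc(C(=O)Nc2ccc3nc(N4CCN(CC)CC4)cc(C)c3c2)cc1`: 9850 nM
Compound 3 `CCN1CCN(c2cc(C)c3cc(NC(=O)c4cccc(Br)c4)ccc3n2)CC1`: 13300 nM

Of the compounds shown here, three have been measured in a functional assay on SK-BR-3 cells (Homo sapiens) for antiproliferative activity, read by MTT assay, with a stated time of 72 h; a lower number here means a stronger inhibitor, a higher number a weaker inhibitor. Compound 2 holds the second highest of the three numbers; compound 3 lies nearest, a 1.4-fold higher number from compound 2 to compound 3 (0.13 log units; within the scatter), and compound 1 lies furthest, with a lower number that is also within the scatter. Compound 4 `CCN1CCN(c2cc(C)c3cc(NC(=O)c4ccco4)ccc3n2)CC1` has not yet been measured. It differs from compound 2 by furan-2-yl in place of 4-ethylphenyl on a carbonyl carbon.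

Among the measured compounds shown here, the one measured step that bears on this change is the swap of the aryl group on the carbonyl carbon from compound 2 to compound 3, which gave a 1.4-fold higher number from compound 2 to compound 3 (0.13 log units; within the scatter) and so did not move the number beyond the scatter. On that basis, a step no larger than the scatter is expected in this assay, in no settled direction, giving a 1.2-fold higher number from compound 2 to compound 4 (0.09 log units; within the scatter). Compound 4 is therefore estimated at 12000 nM, with a range from 5000 nM to 30000 nM.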

Compound 4, half-maximal inhibitory concentration: 37500 nM
Compound 4: the middle estimate sits 3.1-fold (0.49 log units) below what was measured, outside the stated range (above it).
By their numbers in this assay, from the lowest: compounds 1, 2 and 3 (each within the scatter of the next); then compound 4.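

In this assay, the change to furan-2-yl on this carbonyl carbon, whose other neighbour is the amide-type nitrogen, is the first among these amides to go beyond the scatter, with a 3.8-fold higher number from compound 2 to compound 4 (0.58 log units; beyond the scatter) and a 2.8-fold higher number from compound 3 to compound 4 (0.45 log units; beyond the scatter) both pointing the same way. Compound 2 and compound 3 had stayed within the scatter of each other, so this place does respond to the group it carries, even though swapping 4-ethylphenyl for 3-bromophenyl did not show it. Nothing measured here accounts for the size or direction of these steps.

From the compounds shown here alone, it remains open whether a plain phenyl, a thiophene or a pyridine ring on the carbonyl carbon would stand with furan-2-yl or with the two substituted phenyl groups. Also open, going by these compounds, is whether the furan-2-yl step would hold with the dimethylaminoethyl amine chain of compound 1.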